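Working notes: from compound 3 to compound 4

The source may hold more compounds than are shown below. What is called first, only, known or untested is meant among the compounds shown, and "the series" means these compounds.

Measured in a functional assay on A549 cells (Homo sapiens) for antiproliferative activity, read by MTT assay, with a stated time of 72 h; on this read-out lower numbers stand for stronger inhibition and higher numbers for weaker inhibition:
- compound 1 `COc1ccc(-c2ccc3ncn(-c4cc(OC)c(OC)c(OC)c4)c3c2)cc1F`: 1430 nM
- compound 2 `COc1cc(-n2cnc3ccc(-c4cc(F)ccc4F)cc32)cc(OC)c1OC`: 7940 nM
- compound 3 `COc1cc(-n2cnc3ccc(-c4ccccc4)cc32)cc(OC)c1OC`: 3060 nM

Compound 3 holds the second highest of the three numbers, with compound 1 lower and compound 2 higher. The next structure is compound 4 `COc1cc(-n2cnc3ccc(-c4cccc(F)c4)cc32)cc(OC)c1OC`, with fluoro in place of hydrogen on an aromatic carbon, phenyl to 3-fluorophenyl (fluoro in place of hydrogen on an aromatic carbon).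

For the measured compounds named here, no measured step isolates this change, but two bear on it. One is a 2.1-fold higher number from compound 1 to compound 3 (0.33 log units; beyond the scatter), and the other is a 2.6-fold lower number from compound 2 to compound 3 (0.41 log units; beyond the scatter). Both are modest and beyond the scatter, and they run in opposite directions. Compound 1 and compound 2 both carry fluoro on this ring, yet their values fall on either side of compound 3, so no clear direction follows. A small change in this assay, within the scatter, is therefore expected. The estimated step is a 1.1-fold higher number from compound 3 to compound 4 (0.06 log units; within the scatter). For compound 4 the expected value is 3500 nM, with an estimated range of 1500 nM to 8000 nM.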

Compound 4, half-maximal inhibitory concentration: 5270 nM
Compound 4: the middle estimate sits 1.5-fold (0.18 log units) below what was measured; measured number inside the range.
By their numbers in this assay, from the lowest: compound 1; then compounds 3, 4 and 2 (each within the scatter of the next, the first and the last beyond it).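

In this assay, fluoro meta to a large group on the phenyl ring gives a 1.7-fold higher number from compound 3 to compound 4 (0.24 log units; within the scatter), so a single fluoro here does not separate from hydrogen. Hydrogen in place of fluoro on the 2,5-difluorophenyl ring gives a 1.5-fold lower number from compound 2 to compound 4 (0.18 log units; within the scatter), which is also within the scatter, so compound 4 lies within the scatter of both compound 3 and compound 2, although those two lie beyond the scatter of each other. Hydrogen in place of methoxy gives a 3.7-fold higher number from compound 1 to compound 4 (0.57 log units; beyond the scatter), so with the 3-fluorophenyl pattern held, the methoxy of compound 1 goes with the lower number.

From the compounds shown here alone, whether a methoxy without fluoro, or a hydroxyl, an amine or a nitrile on this ring, would keep that lower number remains open. Nothing shown here explains these differences.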